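The compounds below may be only part of what the source reports. "The series", "measured", "known", "first", "only" and "open" are said of these compounds alone.

Measured so far:
compound 1, `Cn1c(-c2noc(C3CCN(C(=O)NC4CCCCC4)CC3)n2)nc2ccccc21`, 89 nM
compound 2, `O=C(NC1CC[S+]([O-])CC1)N1CCC(c2nc(-c3ccc4ccccc4n3)no2)CC1`, 850 nM
compound 3, `Cn1c(-c2noc(N3CCN(C(=O)NC4CCCCC4)CC3)n2)nc2ccccc21`, 5 nM

These three compounds were tested in a functional assay on Shh Light II cells (Mus musculus) for inhibition, read by a luciferase reporter; on this read-out higher numbers stand for weaker inhibition and lower numbers for stronger inhibition. Among them, compound 2 gives the highest number, so it is the weakest inhibitor of the three: compound 1 sits well below it, and compound 3 lies furthest below, both gaps beyond the usual scatter.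

Compound 4, `COc1ccccc1OC(=O)N1CCC(c2nc(-c3ccc4ccccc4n3)no2)CC1`, has not yet been measured. It differs from compound 2 in one place:
a group of 9 heavy atoms (7 carbon, 2 oxygen; one six-membered aromatic ring of carbon only) in place of a group of 8 heavy atoms (5 carbon, 1 nitrogen, 1 oxygen, 1 sulfur; one six-membered non-aromatic ring with 1 hetero atom), on a carbonyl carbon

Within the data shown here, no pair of measured compounds differs by just this kind of exchange, so there is no directly comparable step to lean on. What can be said is that compound 2 is the high outlier of the set, and the change removes the group that compound 2 alone carries. The step is therefore expected to be modest and, if anything, toward a lower number, with an estimated 2.1-fold lower number from compound 2 to compound 4 (0.33 log units; beyond the scatter). Compound 4 is estimated at 400 nM, with a likely range from 80 nM to 2000 nM.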

Compound 4, half-maximal inhibitory concentration: 250 nM
Compound 4: the middle estimate sits 1.6-fold (0.20 log units) above what was measured, and the stated range covers the measured number.
By their numbers in this assay, from the lowest: compound 3; then compound 1; then compound 4; then compound 2.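

In this assay, replacing the sulfur-containing ring group on the carbonyl carbon with 2-methoxyphenoxy gives a 3.4-fold lower number from compound 2 to compound 4 (0.53 log units; beyond the scatter), a step beyond the scatter. This position therefore accepts an aromatic ring as well as a non-aromatic one, and inhibition is kept, and even somewhat stronger, with the hydrogen-bond donor count of the entering group at 0 rather than 1. Nothing available here explains the shift.

On these data alone, the ring type, the donor, the sulfur-oxygen unit and the methoxy group all change in this single exchange, so their separate contributions stay unknown. As far as these compounds go, whether a plain phenoxy group without the methoxy, or a benzyloxy group, on the same carbonyl carbon would move the number further also remains open.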